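A Chlorine Moves to Another Place on the Ring

The compounds below may be only part of what the source reports. "The series", "measured", "known", "first", "only" and "open" are said of these compounds alone.

Measured so far:
Compound 1, `CNc1ncccc1C(=O)N/N=C/c1ccccc1`: 67.6%
Compound 2, `CNc1ncccc1C(=O)N/N=C/c1cccc(Cl)c1`: 68.6%

In a functional assay on the whole organism (strain Wistar) for inhibition, with Rattus norvegicus as the target, read by paw edema, with a stated time of 1 h, at a dose of 10 mg/kg by the intraperitoneal route (a higher number here means more inhibition at the dose given (going by the name of the read-out), a lower number less inhibition), compound 1 gives 67.6%. Within the data shown here, of the two numbers it stands lowest, but its only neighbour is compound 2, with 68.6%, and the gap between them lies within the scatter, so the two cannot be told apart. Compound 3, `CNc1ncccc1C(=O)N/N=C/c1ccc(Cl)cc1`, is not yet measured. It differs from compound 1 by chloro in place of hydrogen on an aromatic carbon. Among the measured compounds shown here, one measured step bears on this: a number 1 percentage points higher from compound 1 to compound 2 (within the scatter), the same kind of change made elsewhere on the same ring, and it stayed within the scatter. Nothing measured points to a step beyond the scatter in either direction, so for compound 3 the expected step is a number 0.4 percentage points higher from compound 1 to compound 3 (within the scatter). Compound 3 is therefore estimated at 68%, with a range from 57% to 79%, until the measurement is in hand.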

Compound 3, a percentage reported as inhibition, in the whole organism at one dose (the size of the read-out at that dose, not a potency): 54.7%
Compound 3: the middle estimate sits 13.3 percentage points above what was measured; the measured number lies below the stated range.
By their numbers in this assay, from the lowest: compound 3; then compounds 1 and 2 (each within the scatter of the next).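

At this place, para to a large group, the swap of hydrogen for chloro has a readable effect in this assay: a number 12.9 percentage points lower from compound 1 to compound 3 (beyond the scatter). The same swap elsewhere on the ring gave a number 1 percentage points higher from compound 1 to compound 2 (within the scatter), so across these three compounds the outcome depends on where the chloro sits, not merely on its presence. Nothing available here explains this difference between the two places.

Still open, going by these compounds, is whether the drop belongs to chloro in particular or would come with other groups at this same place. A fluoro, a methoxy group or an amine there could separate those two readings, and each would also show whether any replacement for hydrogen at this place keeps the number near that of compound 1, at 67.6%.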